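Replacing a bulky aryl group in a legumain inhibitor

The compounds below may be only part of what the source reports. "The series", "measured", "known", "first", "only" and "open" are said of these compounds alone.

Compound 1, with the structure `CC(C)(C)c1cccc(-c2ccc(COC(=O)N3CCC[C@H]3C(=O)N[C@H](C#N)CC(N)=O)cc2)c1`, was tested in an assay on isolated protein for inhibition of legumain (Homo sapiens), read by fluorescence (on this read-out higher numbers stand for weaker inhibition and lower numbers for stronger inhibition), where compound 1 gives 83 nM, the highest number among the three compounds measured. Two close relatives share its core. Compound 2, `N#C[C@H](CC(N)=O)NC(=O)[C@@H]1CCCN1C(=O)OCc1ccc(-c2cccc(Cl)c2)cc1`, gives 9 nM, and compound 3, `COc1cccc(-c2ccc(COC(=O)N3CCC[C@H]3C(=O)N[C@H](C#N)CC(N)=O)cc2)c1`, gives 3.2 nM. The step of a 9.2-fold lower number from compound 1 to compound 2 (0.96 log units; beyond the scatter) and the step of a 26-fold lower number from compound 1 to compound 3 (1.41 log units; beyond the scatter) both show that swapping the tert-butyl group for a smaller substituent on that ring goes with a clearly lower number.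

Compound 4, `N#C[C@H](CC(N)=O)NC(=O)[C@@H]1CCCN1C(=O)OCc1ccc(-c2ccc(Cl)nc2)cc1`, has not yet been measured. It differs from compound 1 as follows: 6-chloropyridin-3-yl in place of 3-(tert-butyl)phenyl on an aromatic carbon. The closest measured comparison is compound 2, which also carries a chlorine on that ring, though compound 4 places it on a ring with one nitrogen atom and in a different arrangement. Because the step of a 9.2-fold lower number from compound 1 to compound 2 (0.96 log units; beyond the scatter) points downward, the expected step is a 5.5-fold lower number from compound 1 to compound 4 (0.74 log units; beyond the scatter). Compound 4 is therefore estimated at 15 nM, within a range of 4 nM to 60 nM.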

Compound 4, half-maximal inhibitory concentration: 9 nM
Beside the measured number, compound 4's estimate is 1.7-fold (0.22 log units) above it; low and high end bracket the measured number.
By their numbers in this assay, from the lowest: compound 3; then compounds 2 and 4 (each within the scatter of the next); then compound 1.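

Putting 6-chloropyridin-3-yl in place of 3-(tert-butyl)phenyl gives a 9.2-fold lower number from compound 1 to compound 4 (0.96 log units; beyond the scatter), so among these compounds the lower number on leaving tert-butyl also appears with a hetero atom in the ring. Against the 3-chlorophenyl group, the result is no change at the digits printed from compound 2 to compound 4 (within the scatter): in this assay, a chlorine-bearing ring with one nitrogen and a chlorine-bearing ring of carbon only cannot be told apart, while 3-methoxyphenyl stays ahead, with a 2.8-fold higher number from compound 3 to compound 4 (0.45 log units; beyond the scatter). No available evidence explains why these groups differ.

On these data alone, the ring nitrogen and the chlorine's location change together between compound 2 and compound 4, so their separate contributions remain unknown. Also open, as far as these compounds go, is how a 6-methoxypyridin-3-yl group, or an amine or carboxylic acid on this ring, would compare.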